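Shortening the ether chain on the shared core

The source may hold more compounds than are shown below. What is called first, only, known or untested is meant among the compounds shown, and "the series" means these compounds.

Compound 3 `CCOc1cc2oc(=O)n(CCC(=O)O)c2cc1Cl` carries an ethoxy group on the shared core. In a physicochemical assay for permeability, using PAMPA (on this read-out lower numbers stand for lower permeability and higher numbers for higher permeability), compound 3 gives only a limit, < 10 nm/s. Compound 2 `C[C@@H](Oc1cc2oc(=O)n(CCC(=O)O)c2cc1Cl)c1ccc(F)cn1`, which carries a 5-fluoropyridin-2-yl on the saturated chain carbon bound to an oxygen on an aromatic ring and a saturated chain carbon, gives 31 nm/s in this assay. Compound 1 `Cc1ccnc([C@@H](C)Oc2cc3oc(=O)n(CCC(=O)O)c3cc2Cl)c1`, with 4-methylpyridin-2-yl in that place, gives a limit, < 3 nm/s. Going by the values given here, the step of an at least 10-fold higher number from compound 1 to compound 2 (1.01 log units; beyond the scatter) is the one fully readable step. The step of an at least 3.1-fold lower number from compound 2 to compound 3 (0.49 log units; beyond the scatter) is readable in one direction only, and the step that the two limits leave unreadable from compound 1 to compound 3 cannot be sized because both ends sit at limits (the limit of < 10 nm/s in this assay, at which 1 of the 3 values shown sits, (the limit of < 3 nm/s in this assay, at which 1 of the 3 values shown sits)). Compound 3 thus stands at the low end of the numbers shown, with compound 1 at a limit as well.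

Compound 4 `COc1cc2oc(=O)n(CCC(=O)O)c2cc1Cl` differs from compound 3 by hydrogen in place of methyl on a saturated chain carbon bound to an oxygen on an aromatic ring, that is, ethoxy to methoxy. Among the compounds with values here, no measured step concerns this change; the measured steps all vary the larger group on that carbon. Compound 4 is therefore expected to stay close to compound 3, with an expected step that the limit leaves unreadable from compound 3 to compound 4, not beyond the scatter. Compound 4 is estimated at 5 nm/s, between 1.5 nm/s and 12 nm/s, most likely reported again as a limit.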

Compound 4, apparent permeability: < 3 nm/s
Compound 4 ended at the assay's limit; the forecaster's own chance of this, stated with the estimate: 80%; at least 1.6-fold (0.22 log units) between middle value and limit.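

Compound 3 and compound 4 both sit at limits in this assay, so the step between them cannot be read. The compounds shown leave open how hydrogen in place of methyl on that saturated chain carbon, ethoxy to methoxy, shifts this read-out, since neither compound gives a number beyond its limit.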